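The source may report more compounds than this note shows. Statements on the series, on what has been measured and on what is new or still open speak of the compounds shown alone.

Measured so far:
compound 1 `C/C(=N/NC(=S)N(Cc1ccccc1)Cc1ccccc1)c1ccc(F)cc1`: 160000 nM
compound 2 `Oc1ccccc1/C=N\NC(=S)N(Cc1ccccc1)Cc1ccccc1`: 166000 nM

Two compounds of the shared core have been run in an ADME assay on Vero cells (Chlorocebus sabaeus) for cytotoxicity, read by MTT assay, with a stated time of 72 h; a lower number here means that less compound is tolerated, a higher number that more compound is tolerated. Compound 1 gives 160000 nM. Compound 2 gives 166000 nM. On the numbers shown compound 1 stands lowest, with compound 2 nearest, but the gap between them falls within the scatter, so the two cannot be told apart. Among the measured compounds shown here, no step between measured compounds that differ in one place is available for this series.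

Compound 3 `C/C(=N/NC(=S)N(Cc1ccccc1)Cc1ccccc1)c1ccccc1O` is not yet measured in this assay. It differs from compound 1 as follows: 2-hydroxyphenyl in place of 4-fluorophenyl on a carbon with a double bond to nitrogen. For the measured compounds named here, with no measured step to lean on, and with compound 1 and compound 2 sitting this close, no change beyond the scatter is expected in this assay in either direction. Compound 3 is accordingly estimated at 160000 nM, with a range from 80000 nM to 320000 nM. This amounts to an expected step of no change at the digits printed from compound 1 to compound 3 (within the scatter).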

Compound 3, half-maximal cytotoxic concentration: 160000 nM
For compound 3 middle estimate and measured number coincide at the digits printed; the measured number falls inside the stated range.
By their numbers in this assay, from the lowest: compounds 1, 3 and 2 (each within the scatter of the next).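

In this assay, among the compounds shown here, exchanging 4-fluorophenyl for 2-hydroxyphenyl on a carbon with a double bond to nitrogen gives no change at the digits printed from compound 1 to compound 3 (within the scatter), the first step that can be read. The entering group carries a hydrogen-bond donor and a hydrogen-bond acceptor that the leaving group lacks, yet this exchange does not separate the two compounds in this read-out. Nothing available accounts for the size of this step.

On these data alone, it remains open whether a carboxylic acid or an amine on this aromatic ring, or a longer chain in place of the ring, would move the number beyond the scatter. As far as these compounds go, with a single step at this one place, the response to changes elsewhere on the shared core also remains unknown.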